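The source may hold more compounds than are shown below. What is called first, only, known or untested is meant among the compounds shown, and "the series" means these compounds.

Compound 2 `C/C(=C\CC/C(C)=C/CC[C@@H]1[C@@]2(C)CCC(=O)C(C)(C)[C@H]2CC[C@@]1(C)O)CC/C=C(\C)C(=O)OCc1cn(-c2cccc(Br)c2)nn1` carries a 1-(3-bromophenyl)-1H-1,2,3-triazol-4-yl group on the ester side chain of the shared core. In a functional assay on DU-145 cells (Homo sapiens) for antiproliferative activity, read by MTT assay, with a stated time of 48 h (a lower number here means a stronger inhibitor, a higher number a weaker inhibitor), compound 2 gives > 150000 nM, which is a limit of the assay rather than a number. Compound 1 `C#CCOC(=O)/C(C)=C/CC/C(C)=C/CC/C(C)=C/CC[C@@H]1[C@@]2(C)CCC(=O)C(C)(C)[C@H]2CC[C@@]1(C)O` gives 46100 nM, and compound 3 `C/C(=C\CC/C(C)=C/CC[C@@H]1[C@@]2(C)CCC(=O)C(C)(C)[C@H]2CC[C@@]1(C)O)CC/C=C(\C)C(=O)OCc1cn([C@@H]2C[C@@H](n3cc(C)c(=O)[nH]c3=O)O[C@H]2CO)nn1` gives 13800 nM. Going by the values given here, the one measured step, an at least 3.2-fold higher number from compound 1 to compound 2 (0.51 log units; beyond the scatter), ends at the limit of > 150000 nM in this assay, at which 1 of the 3 values shown sits. Compound 4 `C/C(=C\CC/C(C)=C/CC[C@@H]1[C@@]2(C)CCC(=O)C(C)(C)[C@H]2CC[C@@]1(C)O)CC/C=C(\C)C(=O)OCc1cn(-c2ccc(C(C)(C)C)cc2)nn1` differs from compound 2 by 4-(tert-butyl)phenyl in place of 3-bromophenyl on an aromatic nitrogen. Among the compounds with values here, no measured step exchanges one aryl group for another, so the expectation rests only on compound 2 sitting at its limit and on the weakening seen in an at least 3.2-fold higher number from compound 1 to compound 2 (0.51 log units; beyond the scatter). Compound 4 is expected to stay weak, estimated at 120000 nM, ranging from 40000 nM to 300000 nM, a step of an at least 1.2-fold lower number from compound 2 to compound 4 (0.09 log units; that floor lies within the scatter).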

Compound 4, half-maximal inhibitory concentration: > 150000 nM
Compound 4: no number, only a limit (the forecaster's own chance of this, stated with the estimate: 50%); at least 1.2-fold (0.09 log units) between middle value and limit.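

Going by these compounds alone, compound 2 and compound 4 both end at a limit of the assay rather than a number, so no step between them can be read: the limit of > 150000 nM in this assay, at which 2 of the 4 values shown sit. On these data alone, whether 4-(tert-butyl)phenyl and 3-bromophenyl differ at all in this assay stays open.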